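The source may hold more compounds than are shown below. What is called first, only, known or untested is meant among the compounds shown, and "the series" means these compounds.

The measured compounds: compound 1 `Cc1ccc(S(=O)(=O)NC(=O)Nc2ccc(Cl)c(Cl)c2)s1`, compound 2 `COc1ccc(S(=O)(=O)NC(=O)Nc2ccc(Cl)cc2)s1`, compound 3 `CC(C)(C)c1ccc(S(=O)(=O)NC(=O)Nc2ccc(Cl)cc2)s1`.

In a functional assay on the whole organism (6C3HED cells, Mus musculus) for inhibition, at a dose of 150 mg/kg by the oral route (a lower number here means less inhibition, a higher number more inhibition at the dose given (going by the name of the read-out)), compound 1 gives 24%, compound 2 gives 93% and compound 3 gives 7%. Compound 2 stands highest of the three, beyond the scatter from each of the others. Among the compounds with values here, the only single-place step measured, a number 86 percentage points lower from compound 2 to compound 3 (beyond the scatter), is large. Compound 4 `COc1csc(S(=O)(=O)NC(=O)Nc2ccc(Cl)cc2)c1` differs from compound 2 in another way: 4-methoxythiophen-2-yl in place of 5-methoxythiophen-2-yl on a sulfonyl sulfur. Within the data shown here, no measured step bears directly on a change of this kind, in which the same atoms are joined differently. Because a number 86 percentage points lower from compound 2 to compound 3 (beyond the scatter) was large and downward, a decrease is expected for compound 4, a number 38 percentage points lower from compound 2 to compound 4 (beyond the scatter), though its size is uncertain. Compound 4 is therefore estimated at 55%, between 15% and 90%.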

Compound 4, a percentage reported as inhibition, in the whole organism at one dose (the size of the read-out at that dose, not a potency): 36%
Compound 4: middle estimate off by 19 percentage points, on the high side, and the stated range covers the measured number.
By their numbers in this assay, from the lowest: compound 3; then compound 1; then compound 4; then compound 2.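

In this assay, the change to 4-methoxythiophen-2-yl from 5-methoxythiophen-2-yl on a sulfonyl sulfur gives a number 57 percentage points lower from compound 2 to compound 4 (beyond the scatter). The number at this place therefore depends on how the same atoms are joined, whereas the earlier step exchanged one group for another. Nothing measured here accounts for this difference.

The compounds shown leave open how an ethoxy group, an amine or a carboxylic acid in place of the methoxy group would read out. They also leave open whether either methoxythiophene arrangement keeps its number in another urea partner.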